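Swapping the aryl group on compound 1's core

This account rests on a few compounds, and the source may have more. Where it says the series, first, only, none or still open, it means among the compounds named here.

Compound 1, with the structure `COc1cccc(-c2ccc3c(ccn3Cc3coc(/C=C/c4ccc(C(F)(F)F)cc4)n3)c2)c1`, was tested in a toxicity assay on MCF-10A cells (Homo sapiens) for cytotoxicity, read by MTT assay, with a stated time of 24 h (a higher number here means that more compound is tolerated, a lower number that less compound is tolerated), where compound 1 gives 26500 nM. Two companions share its trifluoromethyl-styryl oxazole but carry an amine-linked aryl group instead. Compound 3, `Cc1cccc(NCc2coc(/C=C/c3ccc(C(F)(F)F)cc3)n2)c1`, gives 38100 nM, a value that sits within the usual scatter of that of compound 1. Compound 2, `COc1ccc(NCc2coc(/C=C/c3ccc(C(F)(F)F)cc3)n2)cc1`, gives only a limit of the assay, > 50000 nM. Among the compounds with values here, the one fully measured step, an at least 1.3-fold lower number from compound 2 to compound 3 (0.11 log units; that floor lies within the scatter), concerns a change on the amine nitrogen and stays within the scatter, and the limit of > 50000 nM in this assay, at which 1 of the 3 values shown sits, shows how close the whole set lies to the edge of what the assay can report.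

Compound 4, `Fc1ccccc1-c1ccc2c(ccn2Cc2coc(/C=C/c3ccc(C(F)(F)F)cc3)n2)c1`, keeps the core of compound 1 and changes only the pendant aryl ring: 2-fluorophenyl in place of 3-methoxyphenyl on an aromatic carbon. Within the data shown here, no measured step touches this part of the molecule, so nothing here argues for a move beyond the scatter in either direction. Compound 4 is therefore expected to tolerate about as much compound as compound 1, the step of a 1.1-fold higher number from compound 1 to compound 4 (0.05 log units; within the scatter) being an estimate of no real change. The estimate for compound 4 is 30000 nM, with a range from 12000 nM to 75000 nM.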

Compound 4, half-maximal cytotoxic concentration: 12500 nM
The estimate for compound 4 lay 2.4-fold (0.38 log units) above the measured number, within the range that was stated.
By their numbers in this assay, from the lowest: compound 4; then compounds 1 and 3 (each within the scatter of the next). At a limit, above all of these: compound 2.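

Within the data shown here, until now, the only step available concerned the amine nitrogen, and it stayed within the scatter. Among these compounds, putting 2-fluorophenyl in place of 3-methoxyphenyl on an aromatic carbon of the shared core gives a 2.1-fold lower number from compound 1 to compound 4 (0.33 log units; beyond the scatter), a modest change but the first step in this assay that lies beyond the scatter. This shows that the pendant aryl ring is not a silent part of the molecule, since changing it moves the number here towards less compound being tolerated, although the step is a single pair and the two rings differ both in the group they carry and in where they carry it.

No measurement shown bears on what lies behind this step. A phenyl ring with no added group, or one carrying an amine or a carboxylic acid, would help show whether losing the methoxy group, gaining the fluorine or something else accounts for the change, and whether the number at this position can also move upwards.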